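Adding Bromine to the Outer Ring of Compound 3

The source may hold more compounds than are shown below. What is called first, only, known or untested is meant among the compounds shown, and "the series" means these compounds.

In an assay on isolated protein for inhibition of histone deacetylase 8 (Homo sapiens) (a higher number here means a weaker inhibitor, a lower number a stronger inhibitor), compound 3 `O=C(CCCCCCCC(=O)c1ccc(-c2ccccc2)cc1)NO` gives 5 nM, the lowest number among the three measured compounds. Compound 1 `COc1ccc(C(=O)CCCCCCCC(=O)NO)cc1` gives 15 nM, and compound 2 `O=C(CCCCCCCC(=O)c1ccc(Br)cc1)NO` gives 45 nM; the steps of a 3.0-fold lower number from compound 1 to compound 3 (0.48 log units; beyond the scatter) and a 9.0-fold lower number from compound 2 to compound 3 (0.95 log units; beyond the scatter) both set compound 3 apart. Compound 4 `O=C(CCCCCCCC(=O)c1ccc(-c2ccc(Br)cc2)cc1)NO` differs from compound 3 by bromo in place of hydrogen on an aromatic carbon, at the position para to a large group. For the measured compounds named here, only one measured step involves bromo, a 3.0-fold higher number from compound 1 to compound 2 (0.48 log units; beyond the scatter), but there bromo replaces methoxy rather than hydrogen, so it offers weak guidance. Going by the values given here, no measured step in this assay sets bromo against hydrogen on any ring. A small step, possibly within the scatter, is therefore expected: a 1.2-fold higher number from compound 3 to compound 4 (0.08 log units; within the scatter). Compound 4 is estimated at 6 nM, with a range from 2 nM to 18 nM.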

Compound 4, half-maximal inhibitory concentration: 2 nM
Beside the measured number, compound 4's estimate is 3.0-fold (0.48 log units) above it, and the stated range covers the measured number.
By their numbers in this assay, from the lowest: compound 4; then compound 3; then compound 1; then compound 2.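

Bromo in place of hydrogen, para to a large group, gives a 2.5-fold lower number from compound 3 to compound 4 (0.40 log units; beyond the scatter) in this assay and so shows that this position responds to a single added atom. Extending the comparison, 4-bromophenyl gives a 23-fold lower number from compound 2 to compound 4 (1.35 log units; beyond the scatter) when it replaces bromo and a 7.5-fold lower number from compound 1 to compound 4 (0.88 log units; beyond the scatter) when it replaces methoxy. No measurement available here accounts for these steps. Going by these compounds, whether chlorine, a methyl group or an amine at this position would match bromo remains open. So does whether a longer chain would change the effect of bromo.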